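Replacing a difluorophenyl on the amide nitrogen

The source may hold more compounds than are shown below. What is called first, only, known or untested is meant among the compounds shown, and "the series" means these compounds.

Compound 1 `CCN(C(=O)c1c(O)c2c(F)cccc2n(C)c1=O)c1ccccc1`: 60%
Compound 2 `COc1cccc2c1c(O)c(C(=O)N(C)c1c(F)cccc1F)c(=O)n2C`: 43%
Compound 3 `COc1cccc2c1c(O)c(C(=O)N(C)c1cccc(C(C)(C)C)c1)c(=O)n2C`: 60%

Of the compounds shown here, three sharing a common core have been measured in a functional assay on the whole organism for inhibition, with Mus musculus as the target, at a dose of 1 mg/kg by the oral route; a higher number here means more inhibition at the dose given (going by the name of the read-out), a lower number less inhibition. Compound 1 gives 60%, compound 3 gives 60%, and compound 2 gives 43%, which is the lowest of the three numbers. Its nearest neighbour is compound 1, whose number is higher by an amount beyond the usual scatter, and compound 3 stands equally far above it. Compound 1 and compound 3 lie within the scatter of each other, so no order between those two can be stated.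

Compound 4 `COc1ccc(N(C)C(=O)c2c(O)c3c(OC)cccc3n(C)c2=O)cc1` has not yet been measured in this assay. It differs from compound 2 in one place: 4-methoxyphenyl in place of 2,6-difluorophenyl on an amide-type nitrogen. For the measured compounds named here, no step between two measured compounds isolates this change, so the expectation for compound 4 rests on where compound 2 stands and on the fact that the other two compounds, with other groups on the amide nitrogen, sit higher. A modest rise is expected, and the step of a number 7 percentage points higher from compound 2 to compound 4 (within the scatter) is estimated to be near the edge of the scatter rather than clearly beyond it. For compound 4 the expected value in this assay is 50%, with a plausible range from 25% to 75%.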

Compound 4, a percentage reported as inhibition, in the whole organism at one dose (the size of the read-out at that dose, not a potency): 84%
Compound 4: the middle estimate sits 34 percentage points below what was measured, and the stated range ends below it.
By their numbers in this assay, from the lowest: compound 2; then compounds 1 and 3 (each within the scatter of the next); then compound 4.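

In this assay, the group on the amide-type nitrogen proves able to move the read-out by a wide margin: with the rest of the molecule unchanged, 4-methoxyphenyl in place of 2,6-difluorophenyl gives a number 41 percentage points higher from compound 2 to compound 4 (beyond the scatter). For the compounds shown here, the earlier compounds offered no step that isolated a single change, so this is the first direct view of this position, and it shows that the exchange of one aromatic group for another is enough to carry the number well beyond the scatter. The two groups have the same heavy-atom count and each holds one six-membered aromatic ring of carbon only, so the step comes with no change in those counts, and nothing measured here tells which feature of the exchange accounts for it.

The compounds shown do not separate any gain from the methoxy group from the loss of the two fluorine atoms, which a plain phenyl on the same nitrogen could address. They also leave open whether an ethoxy group or an amine in place of the methoxy group would keep the number at this level.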